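The source may hold more compounds than are shown below. What is called first, only, known or untested is meant among the compounds shown, and "the series" means these compounds.

Measured so far in a physicochemical assay for lipophilicity, read by HPLC, measured as octanol-water partition; on this read-out higher numbers stand for higher lipophilicity and lower numbers for lower lipophilicity:
Compound 1, `O=C(OC[C@H]1CN(c2ccc(-n3cc(-c4ccccn4)cn3)c(F)c2)C(=O)O1)c1ccccc1`, gives 4.21.
Compound 2, `O=C1O[C@@H](Cn2ccnc2)CN1c1ccc(-n2cc(-c3ccccn3)cn2)c(F)c1`, gives 1.73.
Compound 3, `CCC(=O)NC[C@H]1CN(c2ccc(-n3cc(-c4ccccn4)cn3)c(F)c2)C(=O)O1`, gives 2.2.

Compound 3 stands second highest of the three: the gap is a number 0.47 log units higher from compound 2 to compound 3 (beyond the scatter), and the other is a number 2.01 log units lower from compound 1 to compound 3 (beyond the scatter). Compound 4, `O=CNC[C@H]1CN(c2ccc(-n3cc(-c4ccccn4)cn3)c(F)c2)C(=O)O1`, has not yet been measured. It differs from compound 3 in one place, (hydrogen in place of ethyl on a carbonyl carbon), so the acyl group on the side chain is shortened while everything else in the shared core stays the same.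

Going by the values given here, none of the measured steps makes exactly this change. The steps from compound 1 swap the whole group on the side chain for a different one and were large; the step from compound 2 to compound 3 swaps an aromatic ring for an amide and was modest. Removing two carbons from an acyl chain usually lowers a partition coefficient by a moderate amount, so the estimate is a downward step of about a number 0.90 log units lower from compound 3 to compound 4 (beyond the scatter) in this assay. Compound 4 is therefore expected to give about 1.3, with a likely range from 0.8 to 1.8.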

Compound 4, partition coefficient: 1.19
The estimate for compound 4 lay 0.11 log units above the measured number; the range from low to high includes it.
By their numbers in this assay, from the lowest: compound 4; then compound 2; then compound 3; then compound 1.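

In this assay, going by these compounds alone, shortening propanoyl to formyl gives a number 1.01 log units lower from compound 3 to compound 4 (beyond the scatter) with the rest of the molecule unchanged, so this is the first read of the ethyl on the carbonyl carbon alone, and that small piece counts for a large step. Formylamino in place of 1H-imidazol-1-yl gives a number 0.54 log units lower from compound 2 to compound 4 (beyond the scatter) while propanoylamino lay above compound 2, so the two amides fall on opposite sides of it, and formylamino in place of benzoyloxy gives a number 3.02 log units lower from compound 1 to compound 4 (beyond the scatter) as the widest step so far. Nothing measured here gives a reason for these steps.

As far as these compounds go, two acyl groups only mark two points, so it stays open whether a longer chain such as butanoyl would continue the rise. Where a plain amine at this place would fall, with no carbonyl at all, also stays open.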